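Sigma-1 binding: from a methoxyphenyl to a methoxybenzyl triazole

This account rests on a few compounds, and the source may have more. Where it says the series, first, only, none or still open, it means among the compounds named here.

Compound 1 `COc1cc2c(cc1OC)CN(CCCCNC(=O)c1cn(Cc3cccc(OCCF)c3)nn1)CC2`: 46300 nM
Compound 2 `COc1cc2c(cc1OC)CN(CCNC(=O)c1cn(-c3ccccc3OC)nn1)CC2`: 15500 nM
Compound 3 `COc1cccc(-n2cc(C(=O)NCCN3CCc4cc(OC)c(OC)cc4C3)nn2)c1`: 76700 nM

All three compounds were tested in an assay on membranes from brain for displacement of a labelled ligand from Sigma non-opioid intracellular receptor 1 (Cavia porcellus), read by scintillation counting, with a stated time of 90 min; a higher number here means a weaker inhibitor, a lower number a stronger inhibitor. Among these, compound 3 gives the highest number; compound 1 lies nearest, within the scatter, while compound 2 lies furthest, beyond the scatter. Going by the values given here, the one single-point step among the measured compounds is a 4.9-fold higher number from compound 2 to compound 3 (0.69 log units; beyond the scatter), so moving the methoxy group on the phenyl ring weakened binding by a modest amount.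

The new compound, compound 4 `COc1ccccc1Cn1cc(C(=O)NCCN2CCc3cc(OC)c(OC)cc3C2)nn1`, differs from compound 3 in one place: 2-methoxybenzyl in place of 3-methoxyphenyl on an aromatic nitrogen. This change brings the methoxy group back to the arrangement seen in compound 2, but with a benzyl rather than a phenyl on the triazole nitrogen. Compound 1 also carries a benzyl there, yet its other differences keep it from serving as a direct comparison. Because a 4.9-fold higher number from compound 2 to compound 3 (0.69 log units; beyond the scatter) shows the 2-methoxy arrangement giving the lower number, compound 4 is expected to move back toward compound 2, by a step estimated as a 3.8-fold lower number from compound 3 to compound 4 (0.58 log units; beyond the scatter) in this assay. Compound 4 is therefore estimated at 20000 nM, with a range from 7000 nM to 60000 nM.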

Compound 4, inhibition constant: 18600 nM
Beside the measured number, compound 4's estimate is 1.1-fold (0.03 log units) above it, within the range that was stated.
By their numbers in this assay, from the lowest: compounds 2 and 4 (each within the scatter of the next); then compounds 1 and 3 (each within the scatter of the next).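

Replacing the 2-methoxyphenyl on the aromatic nitrogen with 2-methoxybenzyl gives a 1.2-fold higher number from compound 2 to compound 4 (0.08 log units; within the scatter) in this assay, so the phenyl and benzyl forms cannot be told apart at this position. The change that does read, a 4.1-fold lower number from compound 3 to compound 4 (0.62 log units; beyond the scatter), alters both the place of the methoxy group and the group's link to the nitrogen, yet among compounds 2, 3 and 4 only compound 3, the one with 3-methoxyphenyl, stands apart from the other two. No measurement shown here explains why these numbers differ.

The compounds shown leave open whether 3-methoxybenzyl at this position would give a number like that of compound 3 or like that of compound 4, which would separate the methoxy placement from the benzyl link. They also leave open what an amine or a carboxylic acid on the benzyl ring would do.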